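The source may report more compounds than this note shows. Statements on the series, on what has been measured and on what is new or still open speak of the compounds shown alone.

Measured so far in a functional assay on cells (LY3.7.2C TK-/- cell line, Mus musculus); a higher number here means a weaker inhibitor, a lower number a stronger inhibitor:
- Compound 1 `Cc1ccc2nc(N)nc(O)c2c1Sc1ccc(C(=O)N[C@H](C(=O)O)c2ccccc2)cc1`: 800 nM
- Compound 2 `COC(=O)[C@@H](NC(=O)c1ccc(Sc2c(C)ccc3nc(N)nc(O)c23)cc1)c1ccccc1`: 500 nM

These two compounds share one core and differ only at the end of the side chain, where compound 1 carries a free acid and compound 2 its methyl ester. Their numbers lie within the usual scatter of repeated measurements, so this assay does not separate them, and compound 2 stands level with compound 1.

The next compound, compound 3 `COC(=O)c1cccc([C@H](NC(=O)c2ccc(Sc3c(C)ccc4nc(N)nc(O)c34)cc2)C(=O)OC)c1`, keeps everything in compound 2 but adds one group to the phenyl ring of the side chain: methoxycarbonyl in place of hydrogen on an aromatic carbon. In words, this is methoxycarbonyl in place of hydrogen on an aromatic carbon.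

For the measured compounds named here, only one measured step is available, a 1.6-fold lower number from compound 1 to compound 2 (0.20 log units; within the scatter). Going by the values given here, it was made at a different place, so it offers only weak guidance, and no measured step covers a change on this aromatic carbon. With so little evidence, no step beyond the scatter is expected, in either direction, and the estimate stays close to compound 2 with a wide margin. The expected change is a 1.2-fold higher number from compound 2 to compound 3 (0.08 log units; within the scatter). The estimate for compound 3 is 600 nM, with an expected range from 200 nM to 1800 nM.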

Compound 3, half-maximal inhibitory concentration: 700 nM
Compound 3: middle estimate off by 1.2-fold (0.07 log units), on the low side, and the stated range covers the measured number.
By their numbers in this assay, from the lowest: compounds 2, 3 and 1 (each within the scatter of the next).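

In this assay, placing methoxycarbonyl on an aromatic carbon of the side-chain phenyl ring, meta to a large group, gives a 1.4-fold higher number from compound 2 to compound 3 (0.15 log units; within the scatter), so this assay does not separate the two compounds. The earlier pair showed only a change at the end of the side chain, whereas this step shows that the phenyl ring itself can also carry a group of this size, with 4 heavy atoms and no ring of its own, without a step beyond the scatter. No data shown here give a reason for this result.

On this ring, the compounds shown carry only hydrogen or this one methoxycarbonyl group at this one place, so it remains open whether a carboxylic acid, an amine or a longer chain on the same carbon would also stay within the scatter of compound 2. For the compounds shown here, the phenyl to 3-(methoxycarbonyl)phenyl change is also seen only with the methyl ester at the end of the side chain, which leaves open whether it would read the same with the free acid of compound 1.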